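Methylating the phenol of a naphthyl analogue

This account rests on a few compounds, and the source may have more. Where it says the series, first, only, none or still open, it means among the compounds named here.

Compound 1 `N#CC1=C(N)N(c2ccc(S(N)(=O)=O)cc2)C2=C(CCCC2)C1c1ccccc1O` and compound 2 `COc1ccccc1C1C(C#N)=C(N)N(c2ccc(S(N)(=O)=O)cc2)C2=C1CCCC2` share one core and differ only by methyl in place of hydrogen on an oxygen on an aromatic ring. In a functional assay on Ehrlich cells (Mus musculus) for cytotoxicity, read by trypan blue exclusion, with a stated time of 2 h, tested at 25 ug/mL (on this read-out lower numbers stand for a weaker effect and higher numbers for a stronger effect at the one concentration tested), compound 1 gives 40%, and compound 2 gives 40%; the step between them is no change at the digits printed from compound 1 to compound 2 (within the scatter). Compound 3 `N#CC1=C(N)N(c2ccc(S(N)(=O)=O)cc2)C2=C(CCCC2)C1c1c(O)ccc2ccccc12` differs from compound 1 by 2-hydroxynaphthalen-1-yl in place of 2-hydroxyphenyl on a saturated ring carbon. In this assay compound 3 gives 5%, and it stands lowest of the three: the step is a number 35 percentage points lower from compound 1 to compound 3 (beyond the scatter), and against compound 2 it is a number 35 percentage points lower from compound 2 to compound 3 (beyond the scatter).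

Compound 4 `COc1ccc2ccccc2c1C1C(C#N)=C(N)N(c2ccc(S(N)(=O)=O)cc2)C2=C1CCCC2` has not yet been measured in this assay. It differs from compound 3 by methyl in place of hydrogen on an oxygen on an aromatic ring, the same change, at the same place, that turns compound 1 into compound 2. The expectation for compound 4 rests on that pair, because no change at the digits printed from compound 1 to compound 2 (within the scatter) shows the methyl leaving the read-out untouched. The step from compound 3 to compound 4 is therefore expected to be small, a number 2 percentage points higher from compound 3 to compound 4 (within the scatter). Compound 4 is estimated at 7%, with a likely range from 0% to 20%.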

Compound 4, a percentage reported as activity, at one concentration (the size of the read-out at that concentration, not a potency): 10%
For compound 4 the middle estimate is 3 percentage points below the measured one; low and high end bracket the measured number.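

In this assay, among the compounds shown here, methyl in place of hydrogen on the oxygen of the aromatic ring gives a number 5 percentage points higher from compound 3 to compound 4 (within the scatter), and set beside the earlier step the change carries over from one core to the other without a detectable difference: the same change on two cores in this assay, no change at the digits printed (within the scatter) from compound 1 to compound 2 and a number 5 percentage points higher (within the scatter) from compound 3 to compound 4, 5 percentage points apart, within the scatter of two such steps This rests on only two pairs, both read in one assay at a single concentration, so it says nothing about potency or about any core beyond these two. For the compounds shown here, it also does not show that the methyl is without any effect, only that on these two cores its step stays within the scatter of the read-out.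

The compounds shown carry only hydroxy or methoxy at this place, so what an ethoxy group, a longer chain on the oxygen, or an amine in place of the hydroxy would do remains open. From the compounds shown here alone, it also remains open whether the same outcome would hold on other cores or at other concentrations.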